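Trading the Thiophene for an Indole on the Enone Carbonyl

The source may hold more compounds than are shown below. What is called first, only, known or untested is meant among the compounds shown, and "the series" means these compounds.

Compound 3 `COc1ccc(-c2cc3ccccc3nc2/C=C/C(=O)c2cccs2)cc1` is the strongest of the three measured compounds in a functional assay on MCF7 cells (Homo sapiens) for antiproliferative activity, read by XTT assay, with a stated time of 72 h (a lower number here means a stronger inhibitor, a higher number a weaker inhibitor), with a value of 1030 nM. Compound 1 `COc1ccc(C(=O)/C=C/c2nc3ccccc3cc2-c2ccc(OC)cc2)cc1` gives 7380 nM in this assay, and compound 2 `COc1ccc(-c2cc3ccccc3nc2/C=C/C(=O)c2c(OC)cccc2OC)cc1` gives 4520 nM. The three differ only in the ring on the carbonyl carbon: the step of a 7.2-fold lower number from compound 1 to compound 3 (0.86 log units; beyond the scatter) and the step of a 4.4-fold lower number from compound 2 to compound 3 (0.64 log units; beyond the scatter) both moved beyond the scatter toward the thiophen-2-yl compound, whereas the step of a 1.6-fold lower number from compound 1 to compound 2 (0.21 log units; within the scatter) stayed within the scatter.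

Compound 4 `COc1ccc(-c2cc3ccccc3nc2/C=C/C(=O)c2c[nH]c3ccccc23)cc1` is not yet measured. It differs from compound 3 by 1H-indol-3-yl in place of thiophen-2-yl on a carbonyl carbon. Within the data shown here, no measured step exchanges thiophen-2-yl for a group of this kind, so the two earlier steps on the same carbonyl carbon are the only guide: changing that ring has shifted this assay by a modest amount in each case where it left the scatter. As far as these compounds go, since the direction for this particular exchange is unknown, compound 4 is expected to stay near compound 3, with a step of a 1.5-fold higher number from compound 3 to compound 4 (0.16 log units; within the scatter) that is not confidently beyond the scatter. Compound 4 is therefore estimated at 1500 nM, within a range from 450 nM to 5000 nM in this assay.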

Compound 4, half-maximal inhibitory concentration: > 10000 nM
Compound 4 ended at the assay's limit; the forecaster's own chance of this, stated with the estimate: 3%; middle value at least 6.6-fold (0.82 log units) from the limit.
By their numbers in this assay, from the lowest: compound 3; then compounds 2 and 1 (each within the scatter of the next). At a limit, above all of these: compound 4.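

In this assay compound 4 reads > 10000 nM, which is a limit of the assay and not a number: the limit of > 10000 nM in this assay, at which 1 of the 4 values shown sits. Even so, the ring on the carbonyl carbon now proves able to lose activity, not only to gain it: 1H-indol-3-yl in place of thiophen-2-yl keeps a five-membered aromatic ring with one hetero atom but adds a six-membered aromatic ring of carbon only and a hydrogen-bond donor, and the change gives an at least 9.7-fold higher number from compound 3 to compound 4 (0.98 log units; beyond the scatter), while the exchange for the 2,6-dimethoxyphenyl ring gives an at least 2.2-fold higher number from compound 2 to compound 4 (0.34 log units; beyond the scatter). The comparison with the 4-methoxyphenyl ring cannot be read as a real loss, since it gives only an at least 1.3-fold higher number from compound 1 to compound 4 (0.13 log units; that floor lies within the scatter), so among the rings shown the thiophen-2-yl compound stays clearly ahead of 1H-indol-3-yl while compound 1 cannot be placed against it.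

The compounds shown do not separate the added carbon ring from the indole nitrogen hydrogen, a question that a 1-methylindol-3-yl or a benzothiophen-3-yl ring on the carbonyl carbon would address. They also leave open whether a smaller five-membered ring such as furan-2-yl or pyrrol-2-yl would hold the activity of compound 3.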